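A few compounds are considered here, and "the series" means these few. Any claim that something is new, unique, unknown or untested is made for them only; others in the source may bear on it.

Of the compounds shown here, two of a shared core have already been tested in a functional assay on the whole organism with Mus musculus as the target; on this read-out lower numbers stand for an effect already at smaller amounts and higher numbers for an effect only at larger amounts of compound: compound 1 `O=C(CCC(=O)c1ccc(Cl)cc1)NCCCO` and compound 2 `Cc1ccc(C(=O)CCC(=O)NCCCO)c(C)c1`. For compound 1 the result of > 300 mg/kg is a limit of the assay, not a number. For compound 2 the result of > 150 mg/kg is likewise only a limit. Compound 2 therefore stands at the limit of > 150 mg/kg in this assay, at which 1 of the 2 values shown sits, and the only other result, that of compound 1, stands at the limit of > 300 mg/kg in this assay, at which 1 of the 2 values shown sits. Compound 3 `Cc1ccc(C(=O)CCC(=O)NCCCO)cc1` has not yet been measured; it differs from compound 2 by hydrogen in place of methyl on an aromatic carbon. Among the compounds with values here, with both measured compounds giving only limits, no measured step is available to show how a change on that ring alters the outcome in this assay. The expected step from compound 2 to compound 3 is accordingly a step that the limit leaves unreadable from compound 2 to compound 3, which is no step beyond the scatter. Compound 3 is estimated at 200 mg/kg, with a range from 100 mg/kg to 400 mg/kg, and it is expected that this assay will again return only a limit rather than a number.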

Compound 3, dose for half-maximal effect: > 300 mg/kg
Compound 3 ended at the assay's limit; the forecaster's own chance of this, stated with the estimate: 75%; at least 1.5-fold (0.17 log units) between middle value and limit.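

Compound 3, like compound 1 and compound 2, gives only a limit and not a number in this assay, so no step among these three compounds can be read. The compounds shown leave open at what dose any of them reaches half-maximal effect, and whether exchanging hydrogen, methyl or chloro on an aromatic carbon changes that dose at all.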